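The compounds below may be only part of what the source reports. "The series", "measured", "known", "first", "only" and "open" are said of these compounds alone.

Measured so far in an ADME assay on Vero cells (Chlorocebus sabaeus) for cytotoxicity, read by resazurin assay, with a stated time of 3 days; a higher number here means a weaker inhibitor, a lower number a stronger inhibitor:
compound 1 `CCOCCOC(=O)Nc1cc2nc(C3CCCCC3)[nH]c2cc1N(C)C` — compound 1 gives > 100 ug/mL, a limit of the assay.
compound 2 `CCCCOC(=O)Nc1cc2nc(C3CCCCC3)[nH]c2cc1N(C)C` — compound 2 gives > 100 ug/mL, a limit of the assay.
compound 3 `CN(C)c1cc2[nH]c(C3CCCCC3)nc2cc1NC(=O)c1ccc(OC(F)F)cc1` — compound 3 gives > 100 ug/mL, a limit of the assay.

Compound 3 therefore stands only at a limit in this assay, and the two further values shown beside it are limits as well: the limit of > 100 ug/mL in this assay, at which 3 of the 3 values shown sit. Among the compounds with values here, no compound of the series has yet returned a readable number.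

The next compound, compound 4 `CN(C)c1cc2[nH]c(C3CCCCC3)nc2cc1NC(=O)c1ccc(C(C)(C)C)cc1`, differs from compound 3 at the carbonyl substituent: tert-butyl in place of difluoromethoxy on an aromatic carbon.

Of the measured steps, two bear on the carbonyl substituent. The step from compound 1 to compound 3 reads a step that the two limits leave unreadable from compound 1 to compound 3, and the step from compound 2 to compound 3 reads a step that the two limits leave unreadable from compound 2 to compound 3. The remaining step, from compound 1 to compound 2, is a step that the two limits leave unreadable from compound 1 to compound 2. Nothing in these steps sets a direction for this assay; every change so far has left the read-out at the limit.

Compound 4 is therefore expected to stay at the limit as well, estimated at 100 ug/mL with a range from 50 ug/mL to 200 ug/mL. The expected step from compound 3 to compound 4 is thus a number no higher from compound 3 to compound 4 (the limit leaves the size open), none beyond the scatter.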

Compound 4, half-maximal inhibitory concentration: > 100 ug/mL
Compound 4 was reported as a limit; the forecaster's own chance of this, stated with the estimate: 80%; the middle value sits exactly at the limit.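

In this assay compound 4 gives > 100 ug/mL, a limit of the assay. Within the data shown here, no step from compound 1, compound 2 or compound 3 to compound 4 can be read. The series now stands at one value: the limit of > 100 ug/mL in this assay, at which 4 of the 4 values shown sit. The compounds shown leave open whether any of these carbonyl substituents changes the read-out, as none has a readable number.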